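Replacing a Chloromethyl with a Chloropropylamino on the Carbonyl

The compounds below may be only part of what the source reports. "The series", "measured", "known", "first", "only" and "open" are said of these compounds alone.

Of the compounds shown here, two share one core and have been measured in a functional assay on HT-29 cells (Homo sapiens) for antiproliferative activity, read by sulforhodamine B assay, with a stated time of 48 h; a higher number here means a weaker inhibitor, a lower number a stronger inhibitor. Compound 1 `CC(C)c1ccccc1OS(=O)(=O)c1ccc(NC(=O)CCl)cc1` gives 5600 nM. Compound 2 `O=C(CCl)Nc1ccc(S(=O)(=O)Oc2ccccc2I)cc1` gives 4100 nM. Compound 2 stands within the scatter of compound 1, as the step of a 1.4-fold lower number from compound 1 to compound 2 (0.14 log units; within the scatter) shows. Compound 3 `O=C(NCCCCl)Nc1ccc(S(=O)(=O)Oc2ccccc2I)cc1` differs from compound 2 by (3-chloropropyl)amino in place of chloromethyl on a carbonyl carbon. Within the data shown here, no measured step bears on this change, since the only known step concerns an aromatic carbon. Compound 3 is therefore expected, with little certainty, to give 12000 nM, between 3000 nM and 50000 nM. The expected step is a 2.9-fold higher number from compound 2 to compound 3 (0.47 log units; beyond the scatter).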

Compound 3, half-maximal inhibitory concentration: 9600 nM
Compound 3: middle estimate off by 1.3-fold (0.10 log units), on the high side, and the stated range covers the measured number.
By their numbers in this assay, from the lowest: compounds 2, 1 and 3 (each within the scatter of the next, the first and the last beyond it).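

Among these compounds, the earlier compounds varied only an aromatic carbon, so this is the first look at the carbonyl carbon. In this assay placing (3-chloropropyl)amino there instead of chloromethyl gives a 2.3-fold higher number from compound 2 to compound 3 (0.37 log units; beyond the scatter) and so weakens the compound modestly, while activity remains measurable with this longer group. No available evidence explains this shift. As far as these compounds go, the added nitrogen and the longer chain enter together, so their separate contributions remain unknown. A (2-chloroethyl)amino group or a propylamino group without the chlorine on the same carbonyl would help to separate them.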